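The compounds below may be only part of what the source reports. "The series", "measured", "known", "first", "only" and "open" are said of these compounds alone.

Measured so far in a functional assay on HeLa cells (Homo sapiens) for cytotoxicity, read by MTT assay, with a stated time of 72 h; a lower number here means a stronger inhibitor, a higher number a weaker inhibitor:
- compound 1, `COc1cc(/C=C/C(=O)Nc2cc3c(Nc4ccc(F)c(Cl)c4)ncnc3cc2O[C@H]2CCOC2)cc(OC)c1O`: 27400 nM
- compound 2, `COc1cc(/C=C/C(=O)Nc2cc3c(Nc4ccc(F)c(Cl)c4)ncnc3cc2O[C@H]2CCOC2)cc(OC)c1OC`: 24500 nM
- compound 3, `COc1cc(/C=C/C(=O)Nc2cc3c(Nc4ccc(F)c(Cl)c4)ncnc3cc2OC)cc(OC)c1`: "not determined" (no result reported)

Compound 2 gives the lowest of the two numbers available, but its nearest neighbour is compound 1, and the step of a 1.1-fold lower number from compound 1 to compound 2 (0.05 log units; within the scatter) is within the scatter, so the two stand level; neither is the stronger inhibitor on this evidence. Compound 3, with a methoxy in place of the oxolanyl ether on the shared core, has no value in this assay and gives no guidance.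

Compound 4, `O=C(/C=C/c1ccc(Br)cc1)Nc1cc2c(Nc3ccc(F)c(Cl)c3)ncnc2cc1O[C@H]1CCOC1`, differs from compound 2 as follows: 4-bromophenyl in place of 3,4,5-trimethoxyphenyl on a double-bonded chain carbon bound to a double-bonded chain carbon. Among the measured compounds shown here, no measured step touches this position on the cinnamamide chain; the only step recorded, a 1.1-fold lower number from compound 1 to compound 2 (0.05 log units; within the scatter), concerns a methyl on an oxygen on the trimethoxyphenyl ring and is within the scatter. It says nothing about removing that ring altogether in favour of 4-bromophenyl. For the measured compounds named here, the series as measured sits at weak, micromolar cytotoxicity and shows no sensitivity to the one change tried on this ring.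

With nothing to anchor a shift, compound 4 is expected to remain in the same weak range as compound 2, the step of a 1.1-fold lower number from compound 2 to compound 4 (0.05 log units; within the scatter) being an estimate with no direction beyond the scatter. Compound 4 is therefore estimated at 22000 nM, with a plausible range from 7000 nM to 70000 nM.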

Compound 4, half-maximal inhibitory concentration: 27500 nM
Compound 4: the middle estimate sits 1.3-fold (0.10 log units) below what was measured, and the stated range covers the measured number.
By their numbers in this assay, from the lowest: compounds 2, 1 and 4 (each within the scatter of the next).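

In this assay, 4-bromophenyl in place of 3,4,5-trimethoxyphenyl on a double-bonded chain carbon bound to a double-bonded chain carbon gives a 1.1-fold higher number from compound 2 to compound 4 (0.05 log units; within the scatter), and the same group in place of 4-hydroxy-3,5-dimethoxyphenyl gives a 1.0-fold higher number from compound 1 to compound 4 (0.00 log units; within the scatter). The earlier compounds shown here tested only a methyl on one oxygen of the ring, whereas here the whole group is exchanged, going from 12 heavy atoms to 7 and from 3 hydrogen-bond acceptors to 0, and compound 1, compound 2 and compound 4 still stand level in this readout. No measured evidence available here accounts for this level result.

On these data alone, it remains open whether a 4-aminophenyl or 4-carboxyphenyl in place of 4-bromophenyl, or a longer chain carrying the aromatic ring, would move the number beyond the scatter. Also open, as far as these compounds go, is whether a change elsewhere on the shared core, such as an amine in place of the oxolanyl ether, would matter more than any change at this position.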